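A few compounds are considered here, and "the series" means these few. Any claim that something is new, unique, unknown or untested is made for them only; others in the source may bear on it.

Measured so far in a functional assay on KYSE-70 cells for antiproliferative activity against KYSE-70 cell line (Homo sapiens), read by MTT assay, with a stated time of 72 h; a higher number here means a weaker inhibitor, a lower number a stronger inhibitor:
- compound 1 (`O=C(Nc1cccc(F)c1)c1cc(=O)[nH]c2cc(-c3ccccc3)ccc12`): > 20000 nM as a limit
- compound 2 (`CC(C)(C)c1ccc(-c2ccc3c(C(=O)Nc4cccc(F)c4)cc(=O)[nH]c3c2)cc1`): > 20000 nM as a limit
- compound 3 (`Nc1ccc(-c2ccc3c(C(=O)Nc4cccc(F)c4)cc(=O)[nH]c3c2)cc1`): > 20000 nM as a limit

Compound 3 therefore has no number in this assay and only a limit. Going by the values given here, the series so far gives only the limit of > 20000 nM in this assay, at which 3 of the 3 values shown sit, and so offers no ranking.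

The next change replaces the 4-aminophenyl of compound 3 with 2-fluoropyridin-3-yl to give compound 4 (`O=C(Nc1cccc(F)c1)c1cc(=O)[nH]c2cc(-c3cccnc3F)ccc12`), as counted here: 2-fluoropyridin-3-yl in place of 4-aminophenyl on an aromatic carbon.

Among the compounds with values here, three measured steps bear on this change. They are a step that the two limits leave unreadable from compound 1 to compound 3 and a step that the two limits leave unreadable from compound 2 to compound 3 and a step that the two limits leave unreadable from compound 1 to compound 2 and none of them has a size that can be carried forward. With tert-butyl, amino and neither group, the compounds all stay at the same limit. The expectation is therefore no shift beyond the usual scatter and no particular direction, with a number no higher from compound 3 to compound 4 (the limit leaves the size open) as the estimated step.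

The expected value for compound 4 is 20000 nM with an estimated range from 8000 nM to 40000 nM and it will quite likely be reported only as a limit again.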

Compound 4, half-maximal inhibitory concentration: > 20000 nM
Compound 4 ended at the assay's limit; the forecaster's own chance of this, stated with the estimate: 80%; the middle value lies on the limit itself.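

Going by these compounds alone, no step to compound 4 from compound 1, compound 2 or compound 3 can be read, since all four compounds share one limit and no number: the limit of > 20000 nM in this assay, at which 4 of the 4 values shown sit.

The compounds shown leave open which change to the shared core, if any, would give a number in this assay instead of a limit.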